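The source may report more compounds than this note shows. Statements on the series, on what has been measured and on what is new or still open speak of the compounds shown alone.

Measured so far:
compound 1 `COc1cccc(C(=O)c2ccc(OC)c(OC(=O)CCC(=O)OC[C@@H]3C=C[C@H](n4cc(C)c(=O)[nH]c4=O)O3)c2)c1` — 1580 nM
compound 2 `COc1ccc(C(=O)c2ccc(F)cc2)cc1OCC(=O)OC[C@@H]1C=C[C@H](n2cc(C)c(=O)[nH]c2=O)O1` — 36300 nM

In a functional assay on HeLa cells (Homo sapiens) for antiproliferative activity, read by MTT assay, with a stated time of 48 h (on this read-out higher numbers stand for weaker inhibition and lower numbers for stronger inhibition), compound 1 gives 1580 nM, the lowest of the two numbers; compound 2 gives 36300 nM, a gap beyond the scatter. The two differ in more than one place, so no single step can be read from them. Compound 3 `COc1ccc(C(=O)c2ccc(F)cc2)cc1OC(=O)CCC(=O)OC[C@@H]1C=C[C@H](n2cc(C)c(=O)[nH]c2=O)O1` follows from compound 1 by 4-fluorophenyl in place of 3-methoxyphenyl on a carbonyl carbon; it shares the 4-fluorophenyl with compound 2 and the rest of the structure with compound 1. Within the data shown here, with no matched step available, the direction rests on the two numbers alone, and a moderate weakening is expected, a 3.2-fold higher number from compound 1 to compound 3 (0.50 log units; beyond the scatter). Compound 3 is estimated at 5000 nM, within 1500 nM to 30000 nM.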

Compound 3, half-maximal inhibitory concentration: 17800 nM
Compound 3: middle estimate off by 3.6-fold (0.55 log units), on the low side, within the range that was stated.
By their numbers in this assay, from the lowest: compound 1; then compound 3; then compound 2.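

In this assay the aryl group on this carbonyl carbon proves sensitive: 4-fluorophenyl in place of 3-methoxyphenyl gives a large weakening (an 11-fold higher number from compound 1 to compound 3 (1.05 log units; beyond the scatter)) with the rest of the structure unchanged. Among these compounds, this is the first single-place comparison, and it favours 3-methoxyphenyl at this position. No measurement shown explains the loss. The change alters both substituent and ring position, so these two remain unseparated. 4-Methoxyphenyl or 3-fluorophenyl on the same carbonyl carbon would tell them apart, and unsubstituted phenyl would give the baseline.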